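Series notes: aryl swap at the carbonyl carbon

The source may hold more compounds than are shown below. What is called first, only, known or untested is meant among the compounds shown, and "the series" means these compounds.

Measured so far in an ADME assay on HEK293 cells (Homo sapiens) for antiproliferative activity, read by MTT assay, with a stated time of 24 h; a higher number here means a weaker inhibitor, a lower number a stronger inhibitor:
- compound 1 `COc1cc(C(=O)/C=C/c2cc(-c3cc(OC)c(OC)c(OC)c3)n3nc(-c4ccccc4)cc3n2)cc(OC)c1OC`: compound 1 gives >= 100000 nM, which is a limit of the assay and not a number.
- compound 2 `COc1ccc(-c2cc(/C=C/C(=O)c3cc(OC)c(OC)c(OC)c3)nc3cc(-c4ccccc4)nn23)cc1OC`: compound 2 gives 35000 nM.
- compound 3 `COc1ccc(C(=O)/C=C/c2cc(-c3ccc(OC)cc3)n3nc(-c4ccccc4)cc3n2)cc1`: compound 3 gives 36100 nM.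

Compound 1 stands at the weak end of what has been seen: it sits at the limit of >= 100000 nM in this assay, at which 1 of the 3 values shown sits, so its true value is not known, only where it lies relative to the others. Among the measured compounds shown here, the only step among measured compounds is an at least 2.8-fold lower number from compound 1 to compound 2 (0.45 log units; beyond the scatter), and even that is a comparison against a limit. Compound 2 and compound 3 lie within the scatter of each other.

The unmeasured compound 4 `COc1cc(-c2cc(/C=C/C(=O)c3ccc(Cl)cc3)nc3cc(-c4ccccc4)nn23)cc(OC)c1OC` differs from compound 1 by 4-chlorophenyl in place of 3,4,5-trimethoxyphenyl on a carbonyl carbon. For the measured compounds named here, no measured step changes the group on the carbonyl carbon, so nothing bears directly on this change; compound 3, which carries a 4-methoxyphenyl on that carbon, gives 36100 nM, but it also differs elsewhere from compound 1. With compound 1 known only as a limit, the step of an at least 1.6-fold lower number from compound 1 to compound 4 (0.22 log units; that floor lies within the scatter) can be expected only as a rough guess. Compound 4 is estimated at 60000 nM in this assay, with a range from 20000 nM to 150000 nM, and a fair chance that only a limit is reported.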

Compound 4, half-maximal inhibitory concentration: >= 100000 nM
Compound 4 gave a limit, no number (the forecaster's own chance of this, stated with the estimate: 40%); at least 1.6-fold (0.22 log units) between middle value and limit.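

In this assay, among the compounds shown here, compound 4 returns a limit and not a number, as compound 1 does, so no step from compound 1 to compound 4 can be read: the limit of >= 100000 nM in this assay, at which 2 of the 4 values shown sit. The compounds shown leave open whether 4-chlorophenyl in place of 3,4,5-trimethoxyphenyl on a carbonyl carbon shifts the value at all, with neither true value known.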